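One Side-Chain Extension Examined for Liver-Cell Cytotoxicity

The source may hold more compounds than are shown below. What is called first, only, known or untested is meant among the compounds shown, and "the series" means these compounds.

Measured so far:
Compound 1 `C=C[C@@](C)(/C=C/c1ccc(O)c(/C=C/C(=O)c2ccccc2)c1)CCC=C(C)C` in a functional assay on HepG2 cells (Homo sapiens) for cytotoxicity, with a stated time of 72 h; on this read-out lower numbers stand for an effect already at smaller amounts and higher numbers for an effect only at larger amounts of compound: > 52000 nM
Compound 2 `C=C[C@@](C)(/C=C/c1ccc(O)c(/C=C/c2ccc(Cl)c(Cl)c2)c1)CCC=C(C)C`: > 52000 nM

The two values in this assay are not numbers but limits of the measurement. Compound 1 reaches only the limit > 52000 nM. Compound 2 likewise stops at the limit > 52000 nM. Going by the values given here, the single measured step, a step that the two limits leave unreadable from compound 1 to compound 2, therefore cannot be read, and the evidence reduces to the limit of > 52000 nM in this assay, at which 2 of the 2 values shown sit.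

Compound 3 `COc1ccc(/C=C/[C@@](C)(/C=C/c2ccc(O)c(/C=C/C(=O)c3ccccc3)c2)CCC=C(C)C)cc1` has not yet been measured in this assay. Its change from compound 1 is 2-(4-methoxyphenyl)ethenyl in place of vinyl on a saturated chain carbon bound to a double-bonded chain carbon and two saturated chain carbons. Among the compounds with values here, no measured step touches the saturated chain carbon bound to a double-bonded chain carbon and two saturated chain carbons, so nothing in the data speaks for or against a shift there. With both measured compounds sitting at the limit, the step of a number no higher from compound 1 to compound 3 (the limit leaves the size open) is expected to remain unreadable in this assay. Compound 3 is therefore estimated at 52000 nM, within a range of 15000 nM to 150000 nM, most likely again reported only as a limit.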

Compound 3, half-maximal effective concentration: > 52000 nM
Compound 3: a limit, no number; the forecaster's own chance of this, stated with the estimate: 70%; the middle value lies on the limit itself.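

In this assay compound 3 gives > 52000 nM, again a limit and not a number. The step from compound 1 to compound 3 therefore cannot be read, and what remains is this: the limit of > 52000 nM in this assay, at which 3 of the 3 values shown sit. The compounds shown leave open at what concentration any of them would produce an effect in this assay.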